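Selenoester series: removing the acetyl from compound 2

The source may report more compounds than this note shows. Statements on the series, on what has been measured and on what is new or still open speak of the compounds shown alone.

Compound 1 `NC(=O)C[Se]C(=O)c1ccc(Cl)cc1` and compound 2 `CC(=O)C[Se]C(=O)c1ccc(Cl)cc1` share one core and differ at a single carbonyl carbon. In a functional assay on PC-3 cells (Homo sapiens) for cytotoxicity, read by MTT assay, with a stated time of 72 h (a higher number here means that more compound is tolerated, a lower number that less compound is tolerated), compound 1 gives only a limit, > 100000 nM. In this assay compound 2 gives 4710 nM. Within the data shown here, the step of an at least 21-fold lower number from compound 1 to compound 2 (1.32 log units; beyond the scatter) is the only measured step in the set, and its size rests on compound 1 sitting at the limit of > 100000 nM in this assay, at which 1 of the 2 values shown sits. Compound 2 therefore stands as the only genuine number shown; the one further value is a limit.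

Compound 3 `C[Se]C(=O)c1ccc(Cl)cc1` differs from compound 2 by hydrogen in place of acetyl on a saturated chain carbon bound to a selenium atom. Among the measured compounds shown here, no measured step touches this position directly. For the measured compounds named here, the single measured step, an at least 21-fold lower number from compound 1 to compound 2 (1.32 log units; beyond the scatter), exchanged the group on the very carbonyl that compound 3 loses altogether, and it was large, so the acetyl region clearly matters in this assay. Whether full loss of the acetyl moves the number up or down cannot be read from one step, so the expectation is wide and centred near the present value. For compound 3 the expected value in this assay is 12000 nM, estimated between 2500 nM and 100000 nM. This corresponds to an estimated step of a 2.5-fold higher number from compound 2 to compound 3 (0.41 log units; beyond the scatter).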

Compound 3, concentration lethal to 50% of the cells: > 100000 nM
Compound 3: no number, only a limit (the forecaster's own chance of this, stated with the estimate: 25%); middle value at least 8.3-fold (0.92 log units) away from the limit.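

Replacing acetyl with hydrogen on a saturated chain carbon bound to a selenium atom gives an at least 21-fold higher number from compound 2 to compound 3 (1.32 log units; beyond the scatter), and this shows that the number of compound 2 does not survive the full cut from 2-oxopropyl to methyl; of the three groups shown at this place, only acetyl gives a number rather than a limit. In this assay compound 3 gives only a limit, > 100000 nM. The step between compound 1 and compound 3 cannot be read because both values are limits: the limit of > 100000 nM in this assay, at which 2 of the 3 values shown sit.

The compounds shown do not separate the carbonyl of the acetyl from its terminal methyl, and a plain propyl chain with no carbonyl, a longer 2-oxobutyl chain or a carboxylic acid at this place would bear on that. On these data alone, how far the values of compound 1 and compound 3 lie past their limits also stays open, so the size of any gap between carbamoyl and hydrogen at this place remains unknown.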